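A Chloro on the Phenyl of Compound 2

This account rests on a few compounds, and the source may have more. Where it says the series, first, only, none or still open, it means among the compounds named here.

In an ADME assay on BHK-21 cells (Mesocricetus auratus) for cytotoxicity, read by MTT assay (on this read-out lower numbers stand for higher toxicity in this test and higher numbers for lower toxicity in this test), compound 1 (`C/C(=N\O)c1ccc2[nH]c(-c3ccc(Cl)cc3)nc2c1`) gives 33000 nM and compound 2 (`C/C(=N\NC(N)=S)c1ccc2[nH]c(-c3ccccc3)nc2c1`) gives 32000 nM so the two stand within the scatter of each other. Compound 3 (`C/C(=N\NC(N)=S)c1ccc2[nH]c(-c3ccc(Cl)cc3)nc2c1`) is still unmeasured and differs from compound 2 by chloro in place of hydrogen on an aromatic carbon in one place, with chloro in place of hydrogen on an aromatic carbon. For the measured compounds named here, no measured pair shows this change alone. Compound 1 also carries 4-chlorophenyl and gives 33000 nM in this assay so little movement is expected. The estimated step of a 1.3-fold lower number from compound 2 to compound 3 (0.11 log units; within the scatter) is expected to stay within the scatter. The expected value for compound 3 is 25000 nM (10000 nM to 60000 nM).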

Compound 3, half-maximal cytotoxic concentration: > 100000 nM
Compound 3 was reported as a limit (the forecaster's own chance of this, stated with the estimate: 10%); middle value at least 4.0-fold (0.60 log units) from the limit.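

In this assay, chloro in place of hydrogen on the phenyl ring gives an at least 3.1-fold higher number from compound 2 to compound 3 (0.49 log units; beyond the scatter), so this position does move the read-out, towards lower toxicity in this test. With 4-chlorophenyl held fixed, a group of 4 heavy atoms in place of one oxygen atom on the double-bonded nitrogen gives an at least 3.0-fold higher number from compound 1 to compound 3 (0.48 log units; beyond the scatter), so 4-chlorophenyl alone does not set the value. The value of compound 3 is a limit, and both steps are minimum sizes: the limit of > 100000 nM in this assay, at which 1 of the 3 values shown sits.

As far as these compounds go, how far compound 3 lies past that limit remains open. So does whether fluoro, methoxy or an amine at the same place would shift the read-out as chloro does.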